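From 4-Fluorophenyl to 1H-Indol-3-yl on a Shared Core

A few compounds are considered here, and "the series" means these few. Any claim that something is new, unique, unknown or untested is made for them only; others in the source may bear on it.

Of the compounds shown here, three have been tested so far in a functional assay on A549 cells (Homo sapiens) for inhibition, read by CCK-8 assay, with a stated time of 48 h (on this read-out higher numbers stand for weaker inhibition and lower numbers for stronger inhibition), and only one of them gives a number. Compound 1 `COc1cc(-c2cc3nccc(-c4cc(OC)c(OC)c(OC)c4)n3n2)cc(OC)c1OC` gives > 10000 nM, which is a limit of the assay and not a number. Compound 3 `COc1cc(-c2cc3nccc(-c4c[nH]c5ccccc45)n3n2)cc(OC)c1OC` gives > 10000 nM, again only a limit. These two results mark (the limit of > 10000 nM in this assay, at which 2 of the 3 values shown sit). Going by the values given here, compound 2 `COc1cc(-c2ccnc3cc(-c4ccc(F)cc4)nn23)cc(OC)c1OC` gives 3800 nM in this assay, the only true number.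

The next compound starts from compound 2. In compound 4 `COc1cc(-c2ccnc3cc(-c4c[nH]c5ccccc45)nn23)cc(OC)c1OC`, 1H-indol-3-yl stands in place of 4-fluorophenyl on an aromatic carbon of the five-membered aromatic ring with 2 nitrogen, and the rest of the molecule is unchanged: 1H-indol-3-yl in place of 4-fluorophenyl on an aromatic carbon.

Among the compounds with values here, no measured pair shows what such an exchange does, so the expectation is a judgement anchored on compound 2 at 3800 nM, and it is held loosely. A move towards stronger inhibition in this assay, beyond the scatter, is expected. The expected change is a 7.6-fold lower number from compound 2 to compound 4 (0.88 log units; beyond the scatter). For compound 4 the estimated value is 500 nM, with an expected range from 40 nM to 6000 nM.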

Compound 4, half-maximal inhibitory concentration: 29 nM
The estimate for compound 4 lay 17-fold (1.24 log units) above the measured number; the measured number lies below the stated range.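

In this assay, exchanging 4-fluorophenyl for 1H-indol-3-yl on the five-membered aromatic ring with 2 nitrogen gives a 130-fold lower number from compound 2 to compound 4 (2.12 log units; beyond the scatter), which shows that the group at this position has a large bearing on the read-out. Going by these compounds alone, this is the first exchange that can be read as a step, as both partners give true numbers. That sets them apart from the other two compounds, whose values are limits and not numbers: the limit of > 10000 nM in this assay, at which 2 of the 4 values shown sit. 

What the compounds shown leave open is which part of the change carries the step, as the entering group brings a five-membered aromatic ring with 1 hetero atom and a hydrogen-bond donor together, and 4-fluorophenyl leaves with its fluorine at the same time. Going by these compounds, a naphthyl group, which has no ring nitrogen, or 1-methyl-1H-indol-3-yl, which lacks the indole hydrogen, would pull these apart at this position, and how an amine or a carboxylic acid would read there also remains open.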